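Changing the aromatic group on a slowly cleared compound

The compounds below may be only part of what the source reports. "The series", "measured", "known", "first", "only" and "open" are said of these compounds alone.

Measured in an ADME assay on microsomes from liver (Homo sapiens) for metabolic stability; a higher number here means faster removal of the compound, a lower number slower removal:
Compound 1 `COc1ccc(-c2cc3c(C)nc(N)nc3n([C@H]3CC[C@@H](OCO)CC3)c2=O)cn1` gives 55.7 mL.min-1.g-1
Compound 2 `COc1ncc(-c2cc3c(C)nc(N)nc3n([C@H]3CC[C@@H](OCO)CC3)c2=O)cc1F` gives 142 mL.min-1.g-1
Compound 3 `COc1ncc(-c2cc3c(C)nc(N)nc3n([C@H]3CC[C@H](OCO)CC3)c2=O)cc1F` gives < 8 mL.min-1.g-1 (a limit, not a number)

Compound 3 stands at the limit of < 8 mL.min-1.g-1 in this assay, at which 1 of the 3 values shown sits, and so has a limit rather than an exact value. Compound 4 `Cc1nc(N)nc2c1cc(-c1cnc3ccccc3c1)c(=O)n2[C@H]1CC[C@H](OCO)CC1` keeps the rest of compound 3, including its configuration, and changes one group: quinolin-3-yl in place of 5-fluoro-6-methoxypyridin-3-yl on an aromatic carbon.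

Going by the values given here, two measured steps bear on this change. The first is modest: a 2.5-fold higher number from compound 1 to compound 2 (0.41 log units; beyond the scatter) came from fluoro in place of hydrogen on an aromatic carbon. It shows that a small edit to the group now leaving can shift the number, although it was seen in the other configuration. The second is large: an at least 17-fold lower number from compound 2 to compound 3 (1.24 log units; beyond the scatter) goes with the fact that compounds 2 and 3 differ only in the configuration as drawn as the only difference. Since compound 4 shares the configuration of compound 3, it is expected to stay low in this assay despite the new group.

For compound 4 a modest rise is expected, with an at least 1.5-fold higher number from compound 3 to compound 4 (0.17 log units; that floor lies within the scatter) as the estimated step. The estimated value for compound 4 is 12 mL.min-1.g-1 with an expected range from 5 mL.min-1.g-1 to 35 mL.min-1.g-1 as its limits.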

Compound 4, intrinsic clearance in microsomes: < 8 mL.min-1.g-1
Compound 4: a limit, no number; the forecaster's own chance of this, stated with the estimate: 35%; at least 1.5-fold (0.17 log units) between middle value and limit.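

Compound 3 and compound 4 both stand at a limit in this assay, not at an exact number, and the step between them cannot be read. The compounds shown leave open whether quinolin-3-yl and 5-fluoro-6-methoxypyridin-3-yl differ at all in this configuration, and how quinolin-3-yl would read in the other configuration.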